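A few compounds are considered here, and "the series" means these few. Any claim that something is new, unique, unknown or untested is made for them only; others in the source may bear on it.

Compound 1 `CN(C)CCCN(C)c1c(N)c(=O)c1=O`: 1070000 nM
Compound 2 `CCNc1c(N(C)CCCN(C)C)c(=O)c1=O`: 900000 nM

In an ADME assay on Vero cells (Chlorocebus sabaeus) for cytotoxicity, read by resazurin assay, with a stated time of 72 h (a higher number here means a weaker inhibitor, a lower number a stronger inhibitor), compound 2 gives 900000 nM, which lies within the scatter of compound 1, so the two cannot be told apart. The next compound, compound 3 `CCCCNc1c(N(C)CCCN(C)C)c(=O)c1=O`, has not yet been measured. It carries butylamino where compound 2 carries ethylamino: ethyl in place of hydrogen on a saturated chain carbon, two bonds along the chain from a nitrogen on an aromatic ring.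

Within the data shown here, only one measured step bears on this change: a 1.2-fold lower number from compound 1 to compound 2 (0.08 log units; within the scatter), which placed ethyl on a nitrogen on an aromatic ring. With that single small step as the guide, no shift beyond the scatter is expected in this assay, and no direction is firmly indicated. The expected step is a 1.3-fold lower number from compound 2 to compound 3 (0.11 log units; within the scatter). For compound 3 the estimated value is 700000 nM, with an expected range from 300000 nM to 1300000 nM.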

Compound 3, half-maximal inhibitory concentration: 439000 nM
Estimate against measurement, compound 3: 1.6-fold (0.20 log units) above; low and high end bracket the measured number.
By their numbers in this assay, from the lowest: compound 3; then compounds 2 and 1 (each within the scatter of the next).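

In this assay the change from ethylamino to butylamino gives a 2.1-fold lower number from compound 2 to compound 3 (0.31 log units; beyond the scatter) and is the first step among these compounds to lie beyond the scatter, though it is modest. Set against hydrogen at the same nitrogen, the butyl group gives a 2.4-fold lower number from compound 1 to compound 3 (0.39 log units; beyond the scatter) as a second modest step, whereas ethyl on that nitrogen stayed within the scatter, so a difference at this nitrogen becomes readable here only with the butyl group of compound 3. No measurement shown here accounts for this shift.

Going by these compounds, whether the number keeps falling with a longer chain such as hexyl, or how a cyclohexyl ring or a terminal amine would fare at this nitrogen, remains open. Propyl is open too, so the chain length at which the step first appears cannot be told.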